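The source may report more compounds than this note shows. Statements on the series, on what has been measured and on what is new or still open speak of the compounds shown alone.

Compound 1, `Cn1c(SCC(=O)Nn2c(COc3ccc(Cl)cc3Cl)nc3ccccc3c2=O)nc(-c2ccc(Cl)cc2)c(C#N)c1=O`: 73.7%
Compound 2, `N#Cc1c(Cl)nc(SCC(=O)Nn2c(COc3ccc(Cl)cc3Cl)nc3ccccc3c2=O)nc1-c1ccccc1`: 66.7%

Both compounds were tested in a functional assay on the whole organism (strain albino) for inhibition, with Rattus norvegicus as the target, read by paw edema, with stated times of 1 h and 2 h, at a dose of 100 mg/kg by the oral route; a lower number here means less inhibition, a higher number more inhibition at the dose given (going by the name of the read-out). Compound 2 has the lower of the two numbers, but its gap to compound 1 lies within the usual scatter of this kind of measurement, so the two results are best read as alike rather than as different.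

Compound 3, `N#Cc1c(Cl)nc(SCC(=O)Nn2c(COc3ccc(Cl)cc3Cl)nc3ccccc3c2=O)nc1-c1ccc(Cl)cc1`, has not yet been measured. It differs from compound 2 in one place: chloro in place of hydrogen on an aromatic carbon. Among the compounds with values here, no pair of measured compounds differs by exactly this change, so there is no measured step to lean on. Compound 1 also carries a 4-chlorophenyl, but it differs from compound 3 in another part of the shared core as well, so it gives only a loose hint.

For compound 3 the step is expected to be a number 3.3 percentage points higher from compound 2 to compound 3 (within the scatter), that is, no shift beyond the scatter. Compound 3 is therefore estimated at 70%, with a likely range from 55% to 82%.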

Compound 3, a percentage reported as inhibition, in the whole organism at one dose (the size of the read-out at that dose, not a potency): 68.4%
The estimate for compound 3 lay 1.6 percentage points above the measured number; the range from low to high includes it.
By their numbers in this assay, from the lowest: compounds 2, 3 and 1 (each within the scatter of the next).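

In this assay, within the data shown here, chloro in place of hydrogen on the aromatic carbon gives a number 1.7 percentage points higher from compound 2 to compound 3 (within the scatter) and so, for the first time, the phenyl to 4-chlorophenyl change can be read directly on an otherwise identical compound. The two compounds read as alike, so at this one position and at this one dose the added chloro brings no difference that can be told from the scatter. Nothing measured here offers a reason for this result.

On these data alone, whether an amine, a methoxy group or a carboxylic acid at the same place would give a number clearly apart from those of compound 2 and compound 3 stays open. As far as these compounds go, a single dose also shows only the size of the inhibition, so any difference in potency between the two stays open as well.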